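Sulfonyl Piperidine Analogues: Cytotoxicity Toward Colon Cancer Cells

A few compounds are considered here, and "the series" means these few. Any claim that something is new, unique, unknown or untested is made for them only; others in the source may bear on it.

Measured compounds in an ADME assay on HCT-116 cells (Homo sapiens) for cytotoxicity, read by CellTiter-Glo, with a stated time of 72 h; on this read-out lower numbers stand for stronger inhibition and higher numbers for weaker inhibition:
Compound 1 `CC1CCN(C2CCN(S(=O)(=O)c3cccnc3Cl)CC2)CC1` gives > 10000 nM in this assay.
Compound 2 `CC1CCN(C2CCN(S(=O)(=O)c3ccc(Br)cc3OC(F)(F)F)CC2)CC1` gives > 5000 nM in this assay.
Compound 3 `COc1ccc(-c2ccccc2S(=O)(=O)N2CCC(N3CCC(C)CC3)CC2)cc1` gives > 5000 nM in this assay.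

Each of these values is a limit of this assay rather than a number. Compound 1 sits at the limit of > 10000 nM in this assay, at which 1 of the 3 values shown sits. Compounds 2 and 3 sit at the limit of > 5000 nM in this assay, at which 2 of the 3 values shown sit. For the measured compounds named here, no compound among the three shows a measured cytotoxicity, so no ordering can be drawn from them.

Compound 4 `CC1CCN(C2CCN(S(=O)(=O)c3ccc(Cl)nc3)CC2)CC1` differs from compound 1 in one place: 6-chloropyridin-3-yl in place of 2-chloropyridin-3-yl on a sulfonyl sulfur. Going by the values given here, no measured pair of this kind exists, so the size of this step is unknown. Given that compound 1 stands at the limit of > 10000 nM in this assay, at which 1 of the 3 values shown sits, compound 4 is expected to remain near the same limit, and the step from compound 1 to compound 4 is expected to be a step that the limit leaves unreadable from compound 1 to compound 4, within the scatter. Compound 4 is thus estimated at 20000 nM in this assay, with a range from 8000 nM to 60000 nM.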

Compound 4, half-maximal inhibitory concentration: > 10000 nM
Compound 4 ended at the assay's limit (the forecaster's own chance of this, stated with the estimate: 85%); the middle value is on the limit's open side.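

Compound 1 and compound 4 each stand at a limit rather than a number, so no step can be read between them: the limit of > 10000 nM in this assay, at which 2 of the 4 values shown sit.

The compounds shown leave open how strong the cytotoxicity of any of them is in this assay.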